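Compound 3 to compound 4: amino to piperazinyl ester

A few compounds are considered here, and "the series" means these few. Any claim that something is new, unique, unknown or untested is made for them only; others in the source may bear on it.

In an ADME assay on L6 cells (Rattus norvegicus) for cytotoxicity, read by resazurin assay, with a stated time of 72 h (on this read-out lower numbers stand for stronger inhibition and higher numbers for weaker inhibition), compound 1 `CCN(CC)CC(=O)OC1CC2(N3CCCCC3)CC(c3ccccc3)C1C(c1ccccc1)C2` gives 23900 nM, compound 2 `CN1CCN(CCC(=O)NC2CC3(N4CCCCC4)CC(c4ccccc4)C2C(c2ccccc2)C3)CC1` gives 61100 nM and compound 3 `NC1CC2(N3CCCCC3)CC(c3ccccc3)C1C(c1ccccc1)C2` gives 35000 nM. Compound 3 thus lies within the scatter of both others. Compound 4 `CN1CCN(CC(=O)OC2CC3(N4CCCCC4)CC(c4ccccc4)C2C(c2ccccc2)C3)CC1` differs from compound 3 by (((4-methylpiperazin-1-yl)methyl)carbonyl)oxy in place of amino on a saturated ring carbon, with (((4-methylpiperazin-1-yl)methyl)carbonyl)oxy in place of amino on a saturated ring carbon. The closest measured parallel is the ester-to-amino step a 1.5-fold higher number from compound 1 to compound 3 (0.17 log units; within the scatter), which is small. The step of a 1.7-fold lower number from compound 2 to compound 3 (0.24 log units; within the scatter) is also small, and only the modest 2.6-fold higher number from compound 1 to compound 2 (0.41 log units; beyond the scatter) exceeds the scatter. No step beyond the scatter is therefore expected, and the estimated step is a 1.3-fold lower number from compound 3 to compound 4 (0.10 log units; within the scatter). For compound 4 the expected value is 28000 nM, within an estimated range of 14000 nM to 56000 nM.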

Compound 4, half-maximal inhibitory concentration: 29500 nM
The estimate for compound 4 lay 1.1-fold (0.02 log units) below the measured number; the range from low to high includes it.
By their numbers in this assay, from the lowest: compounds 1, 4, 3 and 2 (each within the scatter of the next, the first and the last beyond it).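

In this assay, (((4-methylpiperazin-1-yl)methyl)carbonyl)oxy on this saturated ring carbon reads level with amino (a 1.2-fold lower number from compound 3 to compound 4 (0.07 log units; within the scatter)), and 4-methylpiperazin-1-yl in place of diethylamino on the ester chain also stays within the scatter (a 1.2-fold higher number from compound 1 to compound 4 (0.09 log units; within the scatter)). Against the ((2-(4-methylpiperazin-1-yl)ethyl)carbonyl)amino group, however, the ester gives a modest step beyond the scatter (a 2.1-fold lower number from compound 2 to compound 4 (0.32 log units; beyond the scatter)). Nothing available explains these steps.

Still open, on these data alone, is whether the ester linkage or the chain length sets that step, since the two differ together. As far as these compounds go, a carboxylic acid at this ring carbon also remains untested in these compounds.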